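Nitro for methyl on the aryl of compound 2

This account rests on a few compounds, and the source may have more. Where it says the series, first, only, none or still open, it means among the compounds named here.

The shared core carries an ethyl ester in compound 2 `CCOC(=O)c1nn(-c2ccc(C)cc2)/c(=N/c2nc(-c3c(C)n(C)n(-c4ccccc4)c3=O)cs2)s1` and an acetyl in compound 1 `CC(=O)c1nn(-c2ccc([N+](=O)[O-])cc2)/c(=N/c2nc(-c3c(C)n(C)n(-c4ccccc4)c3=O)cs2)s1`. In a functional assay on HepG2 cells (Homo sapiens) for cytotoxicity, read by sulforhodamine B assay, with a stated time of 72 h (on this read-out higher numbers stand for weaker inhibition and lower numbers for stronger inhibition), compound 2 reaches only the limit > 100000 nM. In this assay compound 1 likewise gives the limit > 100000 nM. Both values sit at the limit of > 100000 nM in this assay, at which 2 of the 2 values shown sit. Compound 3 `CCOC(=O)c1nn(-c2ccc([N+](=O)[O-])cc2)/c(=N/c2nc(-c3c(C)n(C)n(-c4ccccc4)c3=O)cs2)s1` brings (nitro in place of methyl on an aromatic carbon), nitro in place of methyl on an aromatic carbon. Among the measured compounds shown here, no measured step covers this change. For compound 3 in this assay the expected step is a step that the limit leaves unreadable from compound 2 to compound 3, none beyond the scatter. Compound 3 is estimated at 150000 nM, range 60000 nM to 500000 nM, most likely again a limit.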

Compound 3, half-maximal inhibitory concentration: 8110 nM
Estimate against measurement, compound 3: 18-fold (1.27 log units) above, outside the stated range (below it).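

In this assay, the 4-methylphenyl to 4-nitrophenyl change gives an at least 12-fold lower number from compound 2 to compound 3 (1.09 log units; beyond the scatter), so this aryl position can move the read-out off the limit. The nitro group is not enough alone: with the 4-nitrophenyl kept, ethoxy in place of methyl on a carbonyl carbon gives an at least 12-fold lower number from compound 1 to compound 3 (1.09 log units; beyond the scatter). Both steps start from a limit, so their true size stays unread: the limit of > 100000 nM in this assay, at which 2 of the 3 values shown sit.

Going by these compounds, whether a nitrile or an amine at the aryl position would act like nitro remains open. So does the effect of a carboxylic acid or a longer chain in place of the ethyl ester.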